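The compounds below may be only part of what the source reports. "The series", "measured", "known", "first", "only" and "open" are said of these compounds alone.

Three fatty-acid amides have been tested in a functional assay on U-251 cells (Homo sapiens) for antiproliferative activity, read by sulforhodamine B assay, with a stated time of 48 h; on this read-out lower numbers stand for stronger inhibition of growth and higher numbers for weaker inhibition of growth. Compound 1 `CCCCCCCC/C=C\CCCCCCCC(=O)N1CCCCC1` gives 6.7 ug/mL. Compound 2 `CCCCCCCCCCCCCCCCCC(=O)N1CCCC1` gives 8 ug/mL, a number within the usual scatter of that of compound 1, so the two cannot be told apart on this read-out. Compound 3 `CCCCCCCCCCCCCCCC(=O)N1CCOCC1` gives 25 ug/mL, a clearly higher number than compound 1, so it inhibits growth less strongly. Of the three numbers, that of compound 1 is the lowest, with compound 2 close beside it and compound 3 set apart.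

The next compound, compound 4 `CCCCC/C=C\C/C=C\CCCCCCCC(=O)N1CCCCC1`, keeps the core of compound 1 and differs in one place: hept-1-en-1-yl in place of heptyl on a saturated chain carbon bound to a double-bonded chain carbon. For the measured compounds named here, no measured pair among the three compounds shows what such a change does in this assay, so the expectation rests on the closeness of the whole series. Since compounds 1 and 2 sit together and the change adds only a double bond in the chain, the step from compound 1 to compound 4 is expected to be small, perhaps a slightly lower number, but likely within the scatter: a 1.2-fold lower number from compound 1 to compound 4 (0.09 log units; within the scatter). Compound 4 is therefore expected to give about 5.5 ug/mL in this assay, in a range from 2.5 ug/mL to 12 ug/mL.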

Compound 4, concentration for 50% growth inhibition: 44.2 ug/mL
For compound 4 the middle estimate is 8.0-fold (0.91 log units) below the measured one, and the stated range ends below it.
By their numbers in this assay, from the lowest: compounds 1 and 2 (each within the scatter of the next); then compounds 3 and 4 (each within the scatter of the next).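

In this assay, the change of heptyl to hept-1-en-1-yl on a saturated chain carbon bound to a double-bonded chain carbon brings a 6.6-fold higher number from compound 1 to compound 4 (0.82 log units; beyond the scatter), so this single edit clearly weakens growth inhibition. For the compounds shown here, this is the first change that can be read on its own, since the earlier compounds differ from one another in more than one place, and it shows that this stretch of the chain is not a silent part of the molecule: the number moves well beyond the scatter, even though the group that leaves and the group that enters hold the same count of carbons. Nothing measured here explains why the added double bond has this effect.

The compounds shown rest on this one step, so they leave open whether the effect is tied to this particular double bond or would also appear with a hept-1-yn-1-yl group or a longer chain at the same place. They also leave open whether the same change would have a similar effect on the amide ends carried by compound 2 and compound 3.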